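The source may report more compounds than this note shows. Statements on the series, on what has been measured and on what is new or still open speak of the compounds shown alone.

This study concerns two compounds built on a shared urea core, with a third yet to be tested. Compound 1, `Cc1cc(CNC(=O)Nc2cc(Cl)nc(Cl)c2)ncc1-c1cn(C)nc1C`, was tested in a functional assay on HFL1 cells for antagonist activity at sphingosine 1-phosphate receptor 2 (Homo sapiens), read by ELISA, with a stated time of 24 h, in the absence of a further agent; a lower number here means a stronger inhibitor, a higher number a weaker inhibitor; in this assay compound 1 gives 0.77 nM. For the measured compounds named here, compound 2, `Cc1cc(CNC(=O)Nc2cc(OCC(O)CO)nc(C(F)(F)F)c2)nnc1-c1cn(C)nc1C(F)(F)F`, differs from compound 1 in several places at once, so no single step between the two can be drawn. For compound 2 this assay reports only a limit, > 11000 nM, so where compound 2 stands is an open range at the weak end rather than a number: the limit of > 11000 nM in this assay, at which 1 of the 2 values shown sits. Compound 3, `Cc1cc(CNC(=O)Nc2cc(OCCO)nc(C(F)(F)F)c2)nnc1-c1cn(C)nc1C(F)(F)F`, has not yet been measured. It differs from compound 2 in one place: hydrogen in place of hydroxymethyl on a saturated chain carbon bound to an oxygen on a saturated carbon and a saturated chain carbon. The change removes one small group from a chain of compound 2 and leaves the rest of the molecule untouched. Going by the values given here, with only a limit for compound 2 and no measured step of this kind, the expected step from compound 2 to compound 3 is a step that the limit leaves unreadable from compound 2 to compound 3, nothing beyond the usual scatter in either direction. Compound 3 is thus expected at about 15000 nM, within a range from 3000 nM to 60000 nM, and most likely again reported only as a limit.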

Compound 3, half-maximal inhibitory concentration: 704 nM
The estimate for compound 3 lay 21-fold (1.33 log units) above the measured number; measured number outside the range, below it.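

In this assay, cutting the 2,3-dihydroxypropoxy group back to 2-hydroxyethoxy gives an at least 15-fold lower number from compound 2 to compound 3 (1.19 log units; beyond the scatter). Since the rest of the molecule stays the same, this one change, hydrogen in place of hydroxymethyl, is enough to turn a compound that reaches only a limit into one with a real number, so this chain is a place where a small edit matters a great deal. The true size of the step stays open, and it can be given only as a minimum because one end of it is a limit: the limit of > 11000 nM in this assay, at which 1 of the 3 values shown sits.

The compounds shown cannot tell whether the outcome depends on the remaining hydroxyl or on the length of the chain; a methoxy group, an amine in place of that hydroxyl, or a longer chain carrying a single hydroxyl would help to separate the two. From the compounds shown here alone, compound 1 and compound 3 differ in several places at once, so it also remains open which of those differences separate their values.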